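Exchanging the Amide Group While the Half-Life Holds

The compounds below may be only part of what the source reports. "The series", "measured", "known", "first", "only" and "open" are said of these compounds alone.

Compound 1 `C=CC(=O)N1CC(NC(=O)Cn2cc(C(=O)N(C)Cc3ccccc3)c3cc(Br)ccc32)C1` is the starting point. In a physicochemical assay for pharmacokinetics, read by LC-MS, in phosphate buffer, at pH 7.4, in the presence of a further agent that is not named here (on this read-out higher numbers stand for a longer-lived compound and lower numbers for a shorter-lived compound), compound 1 gives 1.67 h. Two related compounds carry a different group on the same carbonyl carbon: compound 2 `C=CC(=O)N1CC(NC(=O)Cn2c(C)c(C(=O)N3CCc4c(cccc4OC)C3)c3cc(Cl)ccc32)C1` gives 1.67 h in this assay, and compound 3 `C=CC(=O)N1CC(NC(=O)Cn2c(C)c(C(=O)N3CCc4c(cccc4OC)C3)c3cc(Cl)cc(C)c32)C1` gives 1.67 h. Going by the values given here, the one measured step between them, no change at the digits printed from compound 2 to compound 3 (within the scatter), shows that a methyl in place of hydrogen on an aromatic carbon leaves the half-life where it was. Among the compounds with values here, no single-change step links compound 1 to compound 2 or compound 3; their values simply sit level with one another.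

Compound 4 `C=CC(=O)N1CC(NC(=O)Cn2cc(C(=O)N3CCc4c(cccc4OC)C3)c3cc(Br)ccc32)C1` has not yet been measured. It differs from compound 1 by a group of 12 heavy atoms (10 carbon, 1 nitrogen, 1 oxygen; one six-membered non-aromatic ring with 1 hetero atom, one six-membered aromatic ring of carbon only) in place of a group of 9 heavy atoms (8 carbon, 1 nitrogen; one six-membered aromatic ring of carbon only), on a carbonyl carbon. Within the data shown here, none of the measured steps covers exactly this exchange. Still, compound 2 already carries the entering group and gives 1.67 h, level with compound 1, and the step of no change at the digits printed from compound 2 to compound 3 (within the scatter) is flat. A step of no change at the digits printed from compound 1 to compound 4 (within the scatter) is therefore expected, which is none beyond the scatter. Compound 4 is estimated at 1.67 h, with a range from 1 h to 2.8 h.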

Compound 4, half-life: 1.67 h
For compound 4 middle estimate and measured number coincide at the digits printed, and the stated range covers the measured number.
By their numbers in this assay, from the lowest: compounds 1, 2, 3 and 4 (each within the scatter of the next).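

Going by these compounds alone, until now, the benzyl(methyl)amino group and the group entering here had been seen only on different cores, so their level values said nothing about the exchange on its own. With the core of compound 1 held constant, this assay gives no change at the digits printed from compound 1 to compound 4 (within the scatter), which isolates this exchange: on this carbonyl carbon, a larger group with a second ring system and a hydrogen-bond acceptor can take the place of benzyl(methyl)amino without moving the half-life beyond the scatter. No measurement shown here accounts for this flat result.

This is a single exchange, and all the values shown sit level, so no change at this position has yet been seen to move the half-life. From the compounds shown here alone, whether a smaller amine such as dimethylamino, or a ring such as morpholine, on this carbonyl carbon would also leave the half-life level remains open.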